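The source may hold more compounds than are shown below. What is called first, only, known or untested is meant among the compounds shown, and "the series" means these compounds.

Within the data shown here, compound 1 `O=C(Nc1cccc(-n2cc(-c3ccncc3)c(-c3cc(O)cc(Cl)c3)n2)c1)Nc1ccc(Cl)c(C(F)(F)F)c1` gives -91% in a functional assay on Malme-3M cells (Homo sapiens) for inhibition, read by sulforhodamine B assay, with a stated time of 48 h, tested at 100 uM (a higher number here means a weaker effect of the compound at the concentration tested, a lower number a stronger effect), and stands lowest of the two numbers measured so far; its nearest neighbour is compound 2 `O=C(Nc1cccc(-n2cc(-c3ccncc3)c(-c3cc(O)cc(Cl)c3)n2)c1)Nc1ccc(Cl)c(Cl)c1`, which gives -45% in this assay. Among the measured compounds shown here, the single measured step runs a number 46 percentage points higher from compound 1 to compound 2 (beyond the scatter), a large move at the ring carrying the urea terminus. Compound 3 `COc1cc(Cl)cc(-c2nn(-c3cccc(NC(=O)Nc4ccc(Cl)c(C(F)(F)F)c4)c3)cc2-c2ccncc2)c1` differs from compound 1 in another place: methyl in place of hydrogen on an oxygen on an aromatic ring. For the measured compounds named here, no measured step touches the hydroxy group, so the step from compound 1 to compound 2 does not bear on this change directly; it only shows that the series moves by large amounts under a single substituent change. For compound 3 a step of a number 26 percentage points higher from compound 1 to compound 3 (beyond the scatter) toward a weaker effect is expected, held loosely for want of a comparable measured pair. The estimate for compound 3 in this assay is therefore -65%, in the range -100% to -15%.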

Compound 3, a percentage reported as activity, at one concentration (the size of the read-out at that concentration, not a potency): -35%
Compound 3: middle estimate off by 30 percentage points, on the low side; the range from low to high includes it.
By their numbers in this assay, from the lowest: compound 1; then compounds 2 and 3 (each within the scatter of the next).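

Replacing the hydrogen of the hydroxy group with methyl in this assay gives a number 56 percentage points higher from compound 1 to compound 3 (beyond the scatter), a large move toward a weaker effect. The earlier step showed a large response to a change at the urea terminus; this one shows that the series also responds strongly at the 3-chloro-5-hydroxyphenyl group, so the change from hydroxy to methoxy is not neutral in this pair. The stronger effect goes with the free hydroxy group only in this one pair, and nothing available explains the shift.

From the compounds shown here alone, whether an amine or a fluorine at this place, or a longer chain such as ethoxy, would retain the effect remains open. Also open, going by these compounds, is whether methoxy has a similar effect when chloro replaces trifluoromethyl, as in compound 2.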